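The source may hold more compounds than are shown below. What is called first, only, known or untested is meant among the compounds shown, and "the series" means these compounds.

Measured in a functional assay on WiDr cells (Homo sapiens) for antiproliferative activity, read by sulforhodamine B assay, with a stated time of 48 h; on this read-out higher numbers stand for weaker inhibition of growth and lower numbers for stronger inhibition of growth:

- Compound 1 `CC(C)(C)[Si](C)(C)O[C@@H]1CCCO[C@@H]1COCC(=O)O`: > 100000 nM
- Compound 2 `O=C(COC[C@H]1OCCC[C@@H]1O)OCc1ccccc1`: > 100000 nM
- Compound 3 `O=C1COC[C@H]2OCCC[C@@H]2O1`: > 100000 nM

Each of these entries is a limit of the assay and not a number. Compound 3 gives > 100000 nM, so it offers a limit rather than a true starting value. It shares this position with the other two compounds: the limit of > 100000 nM in this assay, at which 3 of the 3 values shown sit. None of the three therefore shows a measurable potency in this assay.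

Compound 4 `O=C1COC[C@H]2OCCC[C@H]2O1` is built from the same atoms and bonds as compound 3, and only its drawn configuration differs: the two compounds have the same atoms and bonds and differ only in configuration as drawn: 1 of 2 stereo elements differ; a stereocentre at a saturated ring carbon is drawn S in compound 3 and R in compound 4. Among the compounds with values here, no measured pair in this set shows what such a change does. Any expectation is therefore uncertain, and a modest change is the most reasonable guess. The estimated at least 1.4-fold lower number from compound 3 to compound 4 (0.15 log units; that floor lies within the scatter) leans towards stronger inhibition of growth, as compound 3 with > 100000 nM sits at the limit and a move the other way could not be seen.

For compound 4 the expected value is 70000 nM, with an estimated range of 20000 nM to 150000 nM.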

Compound 4, concentration for 50% growth inhibition: > 100000 nM
Compound 4: only a limit was reported (the forecaster's own chance of this, stated with the estimate: 65%); middle value at least 1.4-fold (0.15 log units) away from the limit.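

No step can be read from compound 3 to compound 4, as this assay gives only a limit for each: the limit of > 100000 nM in this assay, at which 4 of the 4 values shown sit.

The compounds shown leave open whether a change in drawn configuration alters growth inhibition at all, and which structures would give a measurable value.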